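The compounds below may be only part of what the source reports. "The series", "measured", "known", "first", "only" and "open" are said of these compounds alone.

Measured in a functional assay on A549 cells (Homo sapiens), read by MTT assay, with a stated time of 72 h (on this read-out higher numbers stand for weaker inhibition and lower numbers for stronger inhibition), each entry a limit and not a number:
- compound 1 `COc1ncnc2c1c(-c1ccccc1)cn2[C@@H]1O[C@H](CO)[C@@H](O)[C@H]1O`: > 20000 nM
- compound 2 `CSc1ncnc2c1c(-c1ccccc1)cn2[C@@H]1O[C@H](CO)[C@@H](O)[C@H]1O`: > 20000 nM
- compound 3 `CNc1ncnc2c1c(-c1ccccc1)cn2[C@@H]1O[C@H](CO)[C@@H](O)[C@H]1O`: > 20000 nM

Compound 1 therefore has no exact position in the series, and the overall picture is the limit of > 20000 nM in this assay, at which 3 of the 3 values shown sit.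

Compound 4 `COc1nc(N)nc2c1c(-c1ccccc1)cn2[C@@H]1O[C@H](CO)[C@@H](O)[C@H]1O` keeps the core and the methoxy group of compound 1. For the measured compounds named here, the single change is amino in place of hydrogen on an aromatic carbon, between two ring nitrogen atoms.

The measured steps exchange the methoxy group and leave this hydrogen untouched, so they bear on the change only weakly. None gives a size: a step that the two limits leave unreadable from compound 1 to compound 2, a step that the two limits leave unreadable from compound 1 to compound 3 and a step that the two limits leave unreadable from compound 2 to compound 3. No step beyond the scatter, in either direction, is expected in this assay.

The expectation starts from compound 1 at > 20000 nM, which is a limit.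

For compound 4 the estimated value is 30000 nM, with an expected range from 10000 nM to 80000 nM.

The expected step is a step that the limit leaves unreadable from compound 1 to compound 4, and a report of only a limit is the likeliest outcome.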

Compound 4, half-maximal inhibitory concentration: > 20000 nM
Compound 4 was reported as a limit (the forecaster's own chance of this, stated with the estimate: 85%); the middle value lies beyond the limit too.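

For the compounds shown here, compound 1 and compound 4 are both reported only as limits in this assay, so no step between them can be read. The compounds shown leave open whether any change on the shared core alters inhibition, with every entry at one value: the limit of > 20000 nM in this assay, at which 4 of the 4 values shown sit.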